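Swapping methoxy for methyl on the pendant phenyl ring

A few compounds are considered here, and "the series" means these few. Any claim that something is new, unique, unknown or untested is made for them only; others in the source may bear on it.

Of the compounds shown here, three of one family have been tested in a functional assay on B16-F10 cells (Mus musculus) for antiproliferative activity, read by MTT assay, with a stated time of 48 h; on this read-out higher numbers stand for weaker inhibition and lower numbers for stronger inhibition. Compound 1 `COc1ccc(-c2csc(N3N=C(c4ccc(C)cc4)CC3c3ccc4c(c3)OCCO4)n2)cc1` gives 2870 nM. Compound 2 `Fc1ccc(C2=NN(c3nc(-c4ccc(Br)cc4)cs3)C(c3ccc4c(c3)OCCO4)C2)cc1` gives 4110 nM. Compound 3 `COc1ccc(C2=NN(c3nc(-c4ccc(Br)cc4)cs3)C(c3ccc4c(c3)OCCO4)C2)cc1` gives 2520 nM. No number shown is lower than that of compound 3, yet both companions sit within the usual scatter of it, so the three are not told apart with confidence. For the measured compounds named here, the one single-point step among them, a 1.6-fold lower number from compound 2 to compound 3 (0.21 log units; within the scatter), is itself inside the scatter.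

Compound 4 `Cc1ccc(C2=NN(c3nc(-c4ccc(Br)cc4)cs3)C(c3ccc4c(c3)OCCO4)C2)cc1` is the next member. It differs from compound 3 by methyl in place of methoxy on an aromatic carbon. Going by the values given here, no measured step changes this position from methoxy to methyl; compound 1 carries a methyl there but also a different group on the other end, so its value and that of compound 3 only show two numbers close together. Among the compounds with values here, with the one step that touches this ring being small, the expected step of a 1.1-fold higher number from compound 3 to compound 4 (0.03 log units; within the scatter) is none beyond the scatter, and compound 4 is expected to give 2700 nM in this assay, within 1300 nM to 5600 nM.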

Compound 4, half-maximal inhibitory concentration: 1680 nM
For compound 4 the middle estimate is 1.6-fold (0.21 log units) above the measured one; measured number inside the range.
By their numbers in this assay, from the lowest: compounds 4, 3, 1 and 2 (each within the scatter of the next, the first and the last beyond it).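

In this assay the change from 4-methoxyphenyl to 4-methylphenyl now has a direct reading (a 1.5-fold lower number from compound 3 to compound 4 (0.18 log units; within the scatter)), and it does not separate the two compounds. For the compounds shown here, the same position also gives the first step beyond the scatter, a modest one, where methyl stands in place of fluoro (a 2.4-fold lower number from compound 2 to compound 4 (0.39 log units; beyond the scatter)). Going by these compounds alone, on the other pendant ring, the first comparison that changes only that ring (a 1.7-fold lower number from compound 1 to compound 4 (0.23 log units; within the scatter)) stays inside the scatter, so bromo and methoxy there are not told apart.

Nothing shown gives a reason why methyl and fluoro differ at this position. Still open, as far as these compounds go, is how the number would respond to a quite different group on this ring, such as an amine, a carboxylic acid or a longer chain.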